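This account rests on a few compounds, and the source may have more. Where it says the series, first, only, none or still open, it means among the compounds named here.

Measured so far:
- Compound 1 `Cc1ccccc1OCC(=O)Nc1ccc(Cl)cc1C(N)=O`: 75.9%
- Compound 2 `NC(=O)c1cc(Cl)ccc1NC(=O)COc1ccc(Cl)cc1Cl`: 18.8%
- Compound 3 `NC(=O)c1cc(I)ccc1NC(=O)COc1ccccc1`: 73%

These three compounds were tested in a functional assay on K562 cells (Homo sapiens) for inhibition, read by trypan blue exclusion, with a stated time of 24 h, tested at 10 uM; on this read-out lower numbers stand for less inhibition of growth and higher numbers for more inhibition of growth at the one concentration tested. Compound 2, at 18.8%, has the lowest number of the three. Compound 3 and compound 1 both stand above it by margins well beyond the usual scatter of this assay.

The next compound to be measured is compound 4 `Cc1ccc(NC(=O)COc2ccc(Cl)cc2Cl)c(C(N)=O)c1`, which differs from compound 2 in one place: methyl in place of chloro on an aromatic carbon. Everything else in compound 2 is kept, including what sets it apart from compound 1 and compound 3 outside this one place.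

Among the compounds with values here, no pair of measured compounds isolates this swap, so the data give no direct guide to its size. The expectation therefore starts from compound 2 at 18.8% and allows only a modest upward move in this assay, with a wide margin of doubt. The expected change is a number 11.2 percentage points higher from compound 2 to compound 4 (beyond the scatter), a small rise in growth inhibition near the edge of the scatter. For compound 4 the estimated value is 30%, with an expected range from 10% to 60%.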

Compound 4, percent growth inhibition at one concentration: 35.4%
Compound 4: the middle estimate sits 5.4 percentage points below what was measured; measured number inside the range.
By their numbers in this assay, from the lowest: compound 2; then compound 4; then compounds 3 and 1 (each within the scatter of the next).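

In this assay, methyl in place of chloro, on the aromatic carbon meta to a carbamoyl group and para to a large group, gives a number 16.6 percentage points higher from compound 2 to compound 4 (beyond the scatter) and so lifts growth inhibition by a modest step. Compounds 2 and 4 form the only pair shown that differs in one place, so this step is the first direct reading of how this position responds: exchanging one heavy atom for another, with no change in ring, hydrogen-bond donors, hydrogen-bond acceptors or net charge, is enough to move the read-out beyond the scatter. The data offer no measured basis for explaining the direction or size of this step.

As far as these compounds go, it remains open whether the rise is specific to methyl or would also appear with another group at this place, such as an amine, a methoxy group or a carboxylic acid. Also open, from the compounds shown here alone, is whether the same exchange would give a step of similar size in compounds that keep the rest of compound 1 or compound 3.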